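A few compounds are considered here, and "the series" means these few. Any claim that something is new, unique, unknown or untested is made for them only; others in the source may bear on it.

Measured so far:
Compound 1 `COc1cccc(Oc2ccc3cc(NC(=O)c4ccc(O)c(CC=C(C)C)c4)c(=O)oc3c2C)c1`; in a functional assay on SK-BR-3 cells (Homo sapiens) for antiproliferative activity (on this read-out higher numbers stand for weaker inhibition and lower numbers for stronger inhibition), compound 1 gives 33100 nM.
Compound 2 `COc1cccc(Cc2ccc3cc(NC(=O)c4ccc(O)c(CC=C(C)C)c4)c(=O)oc3c2C)c1`; in this assay compound 2 gives 14800 nM.

Of these two numbers, compound 2 has the lower one, so it is the stronger inhibitor of the pair. Going by the values given here, the single measured step, a 2.2-fold lower number from compound 1 to compound 2 (0.35 log units; beyond the scatter), changed only the link that joins the outer ring to the shared core and left the outer ring itself untouched. Compound 3 `CC(C)=CCc1cc(C(=O)Nc2cc3ccc(Cc4ccc(O)cc4)c(C)c3oc2=O)ccc1O` keeps that link and instead alters the outer ring: 4-hydroxyphenyl in place of 3-methoxyphenyl on a saturated chain carbon bound to an aromatic carbon. Among the compounds with values here, no measured step concerns a change of this kind, so nothing from compound 1 or compound 2 carries over directly, and the expectation is for a step of at most modest size, in either direction. The estimate for compound 3 in this assay is 11000 nM, with a range from 3500 nM to 35000 nM, which means an expected step of a 1.3-fold lower number from compound 2 to compound 3 (0.13 log units; within the scatter).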

Compound 3, half-maximal inhibitory concentration: 21500 nM
Compound 3: middle estimate off by 2.0-fold (0.29 log units), on the low side; the measured number falls inside the stated range.
By their numbers in this assay, from the lowest: compounds 2, 3 and 1 (each within the scatter of the next, the first and the last beyond it).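

In this assay the exchange of 3-methoxyphenyl for 4-hydroxyphenyl on a saturated chain carbon bound to an aromatic carbon gives a 1.5-fold higher number from compound 2 to compound 3 (0.16 log units; within the scatter) and so leaves compound 2 and compound 3 indistinguishable. The exchange of 3-methoxyphenoxy for 4-hydroxybenzyl on an aromatic carbon gives a 1.5-fold lower number from compound 1 to compound 3 (0.19 log units; within the scatter) and also stays within the scatter, so compound 1 and compound 3 cannot be told apart either. No independent measurement is available to explain these results.

This exchange alters the outer group and its place on the ring together, so 3-hydroxyphenyl or 4-methoxyphenyl would be needed to tell those two changes apart. Going by these compounds, how an amine or a carboxylic acid on the outer ring would read out also remains open.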